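A Pyrrolidine Ring in Place of the Aryl Amide

A few compounds are considered here, and "the series" means these few. Any claim that something is new, unique, unknown or untested is made for them only; others in the source may bear on it.

Compound 1 `O=C(c1ccc(C(F)(F)F)cc1)N1CCC(NS(=O)(=O)c2cc(S(=O)(=O)c3ccccc3)ccc2C(F)(F)F)CC1` is the reference point. Going by the values given here, in an assay on U2OS cells for inhibition of secreted frizzled-related protein 1 (Homo sapiens), read by a luciferase reporter, with a stated time of 18 h (on this read-out lower numbers stand for an effect already at smaller amounts and higher numbers for an effect only at larger amounts of compound), compound 1 gives 970 nM, the highest of the three numbers measured so far. Two compounds share its core. Compound 2 `O=C(c1ccc(Cl)nc1)N1CCC(NS(=O)(=O)c2cc(S(=O)(=O)c3ccccc3)ccc2C(F)(F)F)CC1` gives 140 nM in this assay, so that putting 6-chloropyridin-3-yl in place of 4-(trifluoromethyl)phenyl on the carbonyl carbon gave a 6.9-fold lower number from compound 1 to compound 2 (0.84 log units; beyond the scatter). Compound 3 `CC(C)(O)CCN1CCC(NS(=O)(=O)c2cc(S(=O)(=O)c3ccccc3)ccc2C(F)(F)F)CC1` gives 630 nM in this assay; its step from compound 1 is a 1.5-fold lower number from compound 1 to compound 3 (0.19 log units; within the scatter), and between the other pair the step is a 4.5-fold higher number from compound 2 to compound 3 (0.65 log units; beyond the scatter).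

Compound 4 `O=C([C@H]1CCNC1)N1CCC(NS(=O)(=O)c2cc(S(=O)(=O)c3ccccc3)ccc2C(F)(F)F)CC1` is not yet measured. Its difference from compound 1 is pyrrolidin-3-yl in place of 4-(trifluoromethyl)phenyl on a carbonyl carbon. Both measured steps bear on this change: replacing the aryl group on the carbonyl carbon brought a modest gain in compound 2, while removing the whole aryl carbonyl in compound 3 stayed within the scatter. The pyrrolidine amide of compound 4 is therefore expected to give a number close to that of compound 1, possibly somewhat lower, but not clearly beyond the scatter. Compound 4 is estimated at 600 nM in this assay, with a range from 150 nM to 2400 nM. The expected step is a 1.6-fold lower number from compound 1 to compound 4 (0.21 log units; within the scatter).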

Compound 4, half-maximal effective concentration: 700 nM
Beside the measured number, compound 4's estimate is 1.2-fold (0.07 log units) below it, within the range that was stated.
By their numbers in this assay, from the lowest: compound 2; then compounds 3, 4 and 1 (each within the scatter of the next).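

In this assay, pyrrolidin-3-yl, with 5 heavy atoms and 1 hydrogen-bond donor, replaces 4-(trifluoromethyl)phenyl, with 10 heavy atoms and no donor, on the carbonyl carbon with no readable change (a 1.4-fold lower number from compound 1 to compound 4 (0.14 log units; within the scatter)), so this position accepts a non-aromatic ring as well as an aromatic one. The new amide also cannot be told apart from the hydroxyalkyl amine (a 1.1-fold higher number from compound 3 to compound 4 (0.05 log units; within the scatter)), which keeps the carbonyl from looking essential among these compounds. Only 6-chloropyridin-3-yl stands apart (a 5.0-fold higher number from compound 2 to compound 4 (0.70 log units; beyond the scatter)), so the gain in compound 2 belongs to that group and does not come with every replacement of the 4-(trifluoromethyl)phenyl.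

No measurement shown here explains these results. Still open, going by these compounds, is whether an aminomethyl group, a carboxylic acid or the opposite stereoisomer of pyrrolidin-3-yl on the carbonyl carbon would reach the number of compound 2.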